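The source may report more compounds than this note shows. Statements on the series, on what has been measured and on what is new or still open speak of the compounds shown alone.

Measured in a functional assay on HL-60 cells (Homo sapiens) for antiproliferative activity, read by MTT assay, with a stated time of 72 h; a higher number here means a weaker inhibitor, a lower number a stronger inhibitor:

- compound 1 `COc1cc(-n2ncnc2-c2ccc(Cl)cc2)cc(OC)c1OC`: > 10000 nM
- compound 2 `COc1cc(-n2ncnc2-c2ccc(OC(F)(F)F)cc2)cc(OC)c1OC`: > 10000 nM

Compound 2 stands at > 10000 nM, which is a limit of the assay and not a number. Compound 1 reads > 10000 nM, and this too is a limit. Among the measured compounds shown here, the series so far therefore offers only (the limit of > 10000 nM in this assay, at which 2 of the 2 values shown sit).

Compound 3 `COc1cc(-n2ncnc2-c2ccc(OC(C)C)cc2)cc(OC)c1OC` carries isopropyl in place of trifluoromethyl on an oxygen on an aromatic ring, so that trifluoromethoxy gives way to isopropoxy: isopropyl in place of trifluoromethyl on an oxygen on an aromatic ring.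

For the measured compounds named here, only one measured step bears on this change, a step that the two limits leave unreadable from compound 1 to compound 2. It supplies no size that could be carried over, and it concerns a different exchange. In this assay, going by the values given here, no step of definite size or direction can therefore be forecast from the data. The working expectation is that compound 3 stays close to the limit reached by its two relatives, with a wide margin on the stronger side, since neither relative gives a number. The expected change is an at least 1.2-fold lower number from compound 2 to compound 3 (0.09 log units; that floor lies within the scatter). Compound 3 is estimated at 8000 nM, with an expected range from 500 nM to 30000 nM.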

Compound 3, half-maximal inhibitory concentration: 700 nM
Beside the measured number, compound 3's estimate is 11-fold (1.06 log units) above it; measured number inside the range.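

In this assay, isopropyl in place of trifluoromethyl on an oxygen on an aromatic ring gives an at least 14-fold lower number from compound 2 to compound 3 (1.15 log units; beyond the scatter), and isopropoxy in place of chloro on an aromatic carbon gives an at least 14-fold lower number from compound 1 to compound 3 (1.15 log units; beyond the scatter). Among the compounds shown here, these are the only readable steps, since the step between the other two compounds cannot be read, and they show that the group at this place can decide whether the compound gives a measurable number in this assay. Compound 3 alone has left the limit, which holds for the other two compounds: the limit of > 10000 nM in this assay, at which 2 of the 3 values shown sit.

Going by these compounds, both readable steps start from a limit, so their full size stays open, and a single isopropyl group cannot show whether the gain belongs to that branched group or would extend to other carbon groups on the same oxygen. An ethyl group, a longer chain such as butyl, or a cyclopentyl ring on that oxygen would test this, and an amine or a carboxylic acid on the aromatic carbon would show how far the place tolerates a wholly different kind of group.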